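The source may report more compounds than this note shows. Statements on the series, on what has been measured and on what is new or still open speak of the compounds shown alone.

Working notes on the series. Compound 1 `Cc1c(O)ccc2c1[C@H](Cn1cc(-c3ccc(F)cc3)nn1)[C@@]13CC(=O)[C@@](C)(CC[C@@H]21)C3`, compound 2 `C=C1C[C@]23C[C@@]1(O)CC[C@H]2c1cc(Br)c(O)c(C)c1[C@@H]3Cn1cc(-c2ccc(OC)cc2)nn1`, compound 3 `COc1ccc(-c2cn(C[C@H]3c4c(ccc(OS(=O)(=O)c5ccc(C)cc5)c4C)[C@@H]4CC[C@@]5(C)C[C@]43CC5=O)nn2)cc1` and the untested compound 4 `Cc1ccc(S(=O)(=O)Oc2ccc3c(c2C)[C@H](Cn2cc(-c4ccc(F)cc4)nn2)[C@@]24CC(=O)[C@@](C)(CC[C@@H]32)C4)cc1` share one core. In a functional assay on HL-60 cells (Homo sapiens) for cytotoxicity, read by MTT assay, with a stated time of 4 days (a higher number here means a weaker inhibitor, a lower number a stronger inhibitor), compound 1 gives only a limit, > 20000 nM. Compound 2 likewise reaches only the limit in this assay, > 20000 nM. Compound 3 stands at the same limit in this assay, > 20000 nM, so no number ranks it against the others; all three values sit at the limit of > 20000 nM in this assay, at which 3 of the 3 values shown sit. Compound 4 differs from compound 3 by fluoro in place of methoxy on an aromatic carbon. Compound 1, which already carries fluoro, gives only the limit > 20000 nM. The step from compound 3 to compound 4 is thus expected to stay within scatter, a step that the limit leaves unreadable from compound 3 to compound 4. For compound 4 the estimate is 30000 nM, within 10000 nM to 100000 nM, most likely again a limit.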

Compound 4, half-maximal inhibitory concentration: > 20000 nM
Compound 4 was reported as a limit; the forecaster's own chance of this, stated with the estimate: 85%; the middle value is on the limit's open side.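

Neither the step from compound 3 nor the step from compound 1 to compound 4 can be read, since all these values are limits: the limit of > 20000 nM in this assay, at which 4 of the 4 values shown sit.

The compounds shown leave open which change to the shared core, if any, would give a measured number rather than a limit.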